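The source may report more compounds than this note shows. Statements on the series, on what has been measured and on what is new or still open speak of the compounds shown alone.

Measured compounds in a functional assay on SK-HEP1 cells (Homo sapiens) for antiproliferative activity; on this read-out lower numbers stand for stronger inhibition of growth and higher numbers for weaker inhibition of growth:
compound 1 `CO/N=C(\C)COc1ccc2c(=O)c(-c3ccccc3)coc2c1`: 6400000 nM
compound 2 `O=c1c(-c2ccccc2)coc2cc(OC/C(=N/O)c3ccc(F)cc3)ccc12`: 6610000 nM
compound 3 `CO/N=C(/COc1ccc2c(=O)c(-c3ccccc3)coc2c1)c1ccccc1`: 7400000 nM

All three numbers lie within the scatter of one another, so compound 3 stands level with compounds 1 and 2 rather than apart from them. The step to compound 4 `CO/N=C(/COc1ccc2c(=O)c(-c3ccccc3)coc2c1)c1ccc(F)cc1` is fluoro in place of hydrogen on an aromatic carbon. For the measured compounds named here, one measured step bears on the same carbon: a 1.2-fold higher number from compound 1 to compound 3 (0.06 log units; within the scatter), which changed nothing beyond the scatter. Compound 2 carries the same fluoro on its phenyl, though it differs from compound 3 in a second place too, and its value sits within the scatter of compound 3. A step of about a 1.1-fold lower number from compound 3 to compound 4 (0.02 log units; within the scatter) is therefore expected, none beyond the scatter. Compound 4 is estimated at 7000000 nM, between 3500000 nM and 14000000 nM.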

Compound 4, concentration for 50% growth inhibition: 6100000 nM
For compound 4 the middle estimate is 1.1-fold (0.06 log units) above the measured one, within the range that was stated.
By their numbers in this assay, from the lowest: compounds 4, 1, 2 and 3 (each within the scatter of the next).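

In this assay, for the compounds shown here, the fluoro on the aromatic carbon, tested here on its own for the first time, gives a 1.2-fold lower number from compound 3 to compound 4 (0.08 log units; within the scatter) and so leaves compound 4 level with compound 3. The oxygen and the carbon with a double bond to nitrogen read the same way: methyl in place of hydrogen on the oxygen gives a 1.1-fold lower number from compound 2 to compound 4 (0.03 log units; within the scatter) and 4-fluorophenyl in place of methyl gives a 1.0-fold lower number from compound 1 to compound 4 (0.02 log units; within the scatter) as well. Going by these compounds, whether an amine or a carboxylic acid on that phenyl ring, or a longer chain on the oxygen, would stand apart from these compounds remains open. Nothing available accounts for why these compounds stand level.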